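Chloro in Place of Hydrogen on the Phenyl of Compound 2

The compounds below may be only part of what the source reports. "The series", "measured", "known", "first", "only" and "open" are said of these compounds alone.

Compound 1 `COc1ccc2c(=O)c(/C=C/C(=O)NCc3cccc(F)c3)coc2c1`: 475000 nM
Compound 2 `COc1ccc2c(=O)c(/C=C/C(=O)Nc3ccccc3)coc2c1`: 523000 nM

In an ADME assay on HepG2 2.2.15 cells (Homo sapiens) for cytotoxicity, read by MTT assay, with stated times of 48 h and 9 days (a lower number here means that less compound is tolerated, a higher number that more compound is tolerated), compound 2 gives 523000 nM, and compound 1 gives 475000 nM. Among the compounds with values here, the only measured step, a 1.1-fold higher number from compound 1 to compound 2 (0.04 log units; within the scatter), lies within the scatter, so the two numbers are not distinguished. Compound 3 `COc1ccc2c(=O)c(/C=C/C(=O)Nc3ccc(Cl)cc3)coc2c1` differs from compound 2 by chloro in place of hydrogen on an aromatic carbon. Within the data shown here, no measured step involves a substituent on this ring, and the one step known touched a different part and stayed within the scatter. Compound 3 is therefore expected to show no step beyond the scatter, a 1.0-fold lower number from compound 2 to compound 3 (0.02 log units; within the scatter), with an estimated 500000 nM between 250000 nM and 1000000 nM.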

Compound 3, half-maximal cytotoxic concentration: 272000 nM
The estimate for compound 3 lay 1.8-fold (0.26 log units) above the measured number; low and high end bracket the measured number.
By their numbers in this assay, from the lowest: compounds 3, 1 and 2 (each within the scatter of the next).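

In this assay the first substituent on this phenyl, a chloro para to a large group, gives a 1.9-fold lower number from compound 2 to compound 3 (0.28 log units; within the scatter) as its step, so this position takes the chloro without a step beyond the scatter. The change to 4-chlorophenyl in place of 3-fluorobenzyl gives a 1.7-fold lower number from compound 1 to compound 3 (0.24 log units; within the scatter) and likewise stays within the scatter. No evidence at hand bears on either step. As far as these compounds go, whether an amine or a carboxylic acid at this position would move the number beyond the scatter stays open. So does whether a longer chain on the amide-type nitrogen would do so.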